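Replacing the side-chain amine with a branched alkyl group

The compounds below may be only part of what the source reports. "The series", "measured", "known", "first", "only" and "open" are said of these compounds alone.

Measured so far:
Compound 1, `N=C(N)NCCC[C@H](NC(=O)CN(c1nc(Cl)nc2[nH]cnc12)C1CC1)C(=O)O`: 39.8%
Compound 2, `NCCCC[C@H](NC(=O)CN(c1nc(Cl)nc2[nH]cnc12)C1CC1)C(=O)O`: 31.3%

In a functional assay on the whole organism (Tail, strain ICR) with Mus musculus as the target, in the tail flick test, with a stated time of 60 min, at a dose of 12.5 umol/kg by the oral route (a lower number here means a weaker effect, a higher number a stronger effect of the compound at the dose given), compound 1 gives 39.8%. In this assay compound 2 gives 31.3%, the lowest of the two numbers, with compound 1 as its nearest neighbour, and the step of a number 8.5 percentage points lower from compound 1 to compound 2 (within the scatter) is within the scatter, so the two compounds cannot be told apart on these numbers.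

Compound 3, `CC(C)C[C@H](NC(=O)CN(c1nc(Cl)nc2[nH]cnc12)C1CC1)C(=O)O`, has not been measured. It differs from compound 2 by isopropyl in place of 3-aminopropyl on a saturated chain carbon, two bonds along the chain from an amide-type nitrogen and a carbonyl carbon. Among the compounds with values here, only one measured step exists, a number 8.5 percentage points lower from compound 1 to compound 2 (within the scatter), and it concerns an exchange of nitrogen-containing groups on the same side chain, which was within the scatter. Within the data shown here, no measured step removes the side-chain nitrogen altogether, as the change to compound 3 does, so there is no direct guide. With that uncertainty, the step of a number 4.3 percentage points lower from compound 2 to compound 3 (within the scatter) is expected to stay close to the scatter, leaning slightly lower. The estimate for compound 3 in this assay is 27%, expected between 8% and 48%.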

Compound 3, a percentage reported as activity, at one dose (the size of the read-out at that dose, not a potency): 17.3%
Compound 3: the middle estimate sits 9.7 percentage points above what was measured; low and high end bracket the measured number.
By their numbers in this assay, from the lowest: compound 3; then compounds 2 and 1 (each within the scatter of the next).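

In this assay, within the data shown here, removing the nitrogen from the side chain gives the first readable change at this saturated chain carbon: isopropyl in place of 3-aminopropyl gives a number 14 percentage points lower from compound 2 to compound 3 (beyond the scatter), whereas exchanging one nitrogen-containing group for another gave only a number 8.5 percentage points lower from compound 1 to compound 2 (within the scatter). Compound 1, the other compound with nitrogen in its side chain, also separates from the all-carbon isopropyl group, with a number 22.5 percentage points lower from compound 1 to compound 3 (beyond the scatter), so both nitrogen-containing side chains shown stand apart from it, though both steps are modest. Nothing given here accounts for this difference.

From the compounds shown here alone, what remains open is whether the nitrogen itself matters, since this single change removes the amine and also replaces 3-aminopropyl, with its 4 heavy atoms, by the branched isopropyl, with 3. An unbranched all-carbon chain such as n-butyl, or a side chain ending in a hydroxyl group or a carboxylic acid, would help show whether the chain's shape, its length or the atoms at its end go with the lower number.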